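Chloro to hydroxy: following compound 2 to compound 3

The compounds below may be only part of what the source reports. "The series", "measured", "known", "first", "only" and "open" are said of these compounds alone.

Of the compounds shown here, two have been measured so far in a functional assay on U-251 cells (Homo sapiens) for inhibition, read by MTT assay, with a stated time of 72 h; a lower number here means a stronger inhibitor of growth, a higher number a weaker inhibitor of growth. Compound 1 `O=C1CC(N2C(=O)CSC2=S)C(=O)N1c1ccc(Cl)cc1` reads > 100000 nM, which is a limit of the assay and not a number. For the measured compounds named here, compound 2 `O=C1CC(N2C(=O)/C(=C/C(Cl)=C/c3ccc([N+](=O)[O-])cc3)SC2=S)C(=O)N1c1ccc(Cl)cc1` gives 8930 nM, the only true number, so its standing can be read only against compound 1.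

Compound 3 `O=C1CC(N2C(=O)/C(=C/C(Cl)=C/c3ccc([N+](=O)[O-])cc3)SC2=S)C(=O)N1c1ccc(O)cc1` keeps compound 2 unchanged except at one place: hydroxy in place of chloro on an aromatic carbon. This is hydroxy in place of chloro on an aromatic carbon, para to a large group, or 4-chlorophenyl to 4-hydroxyphenyl when cut one bond further out.

Going by the values given here, no measured pair shows this change, so its size cannot be read from the data. Among the compounds with values here, the single anchor is compound 2 at 8930 nM, and the expectation in this assay is of no shift beyond the scatter, with a lean, if any, toward weaker growth inhibition. The expected 1.2-fold higher number from compound 2 to compound 3 (0.09 log units; within the scatter) is correspondingly small. For compound 3 the estimated value is 11000 nM, with an expected range of 3500 nM to 35000 nM.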

Compound 3, concentration for 50% growth inhibition: 1100 nM
For compound 3 the middle estimate is 10-fold (1.00 log units) above the measured one, and the stated range ends above it.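

In this assay, for the compounds shown here, hydroxy in place of chloro on an aromatic carbon, para to a large group, gives an 8.1-fold lower number from compound 2 to compound 3 (0.91 log units; beyond the scatter), the only step that can be read at a single place. This shows that the position is not silent: the group on this ring changes growth inhibition beyond the scatter, and of the two groups seen here, hydroxy goes with the lower number, with compound 3 at 1100 nM. Nothing measured here bears on the origin of this step.

On these data alone, one pair gives a single step, so it remains open whether the gain is particular to hydroxy or would also appear with an amine, a methoxy or a carboxylic acid at the same position. As far as these compounds go, it is also open whether 4-chlorophenyl to 4-hydroxyphenyl would give a step of similar size if the 4-nitrophenyl end of the chlorinated side chain carried another group, such as an amine, instead of the nitro group.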